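The compounds below may be only part of what the source reports. "The series", "measured", "known", "first", "only" and "open" are said of these compounds alone.

Working notes on the series. Compound 1 `CSCc1c(C)nc2c(OCc3ccccc3)cccn12` gives 29% in a functional assay on the whole organism with Rattus norvegicus as the target, with a stated time of 4 h, at a dose of 40 mg/kg by the intraperitoneal route (a higher number here means more inhibition at the dose given (going by the name of the read-out), a lower number less inhibition), and compound 2 `COC(=O)Cc1c(C)nc2c(OCc3ccccc3)cccn12` gives 23% in this assay; the step of a number 6 percentage points lower from compound 1 to compound 2 (within the scatter) lies within the scatter. Compound 2 thus stands as the lower of the two numbers, with compound 1 within the scatter of it. Compound 3 `Cc1nc2c(OCc3ccccc3)cccn2c1CC(=O)O` differs from compound 2 by hydrogen in place of methyl on an oxygen next to a carbonyl group, methoxycarbonyl to carboxy. Among the compounds with values here, no measured step touches this change; the only step measured, a number 6 percentage points lower from compound 1 to compound 2 (within the scatter), was within the scatter. For compound 3 the expected step of a number 1 percentage points lower from compound 2 to compound 3 (within the scatter) is therefore none beyond the scatter, and its estimated value in this assay is 22%, ranging from 5% to 40%.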

Compound 3, a percentage reported as inhibition, in the whole organism at one dose (the size of the read-out at that dose, not a potency): 12%
The estimate for compound 3 lay 10 percentage points above the measured number, within the range that was stated.
By their numbers in this assay, from the lowest: compound 3; then compounds 2 and 1 (each within the scatter of the next).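

In this assay, within the data shown here, the change from methoxycarbonyl to carboxy gives a number 11 percentage points lower from compound 2 to compound 3 (beyond the scatter), the first step beyond the scatter. Carboxy in place of methylsulfanyl on the same chain carbon also gives a number 17 percentage points lower from compound 1 to compound 3 (beyond the scatter), whereas methoxycarbonyl in that place stayed within the scatter of methylsulfanyl. No measurement at hand bears on what lies behind this drop.

The compounds shown leave open whether the lower number belongs to the carboxylic acid alone. A primary amide at this position, or a longer chain carrying the carboxy group, could settle that.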